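Sulfonylimidazolidinones: chloro removal and cytotoxicity

The compounds below may be only part of what the source reports. "The series", "measured", "known", "first", "only" and "open" are said of these compounds alone.

Measured compounds:
compound 1 `O=C1NC(c2ccccc2)CN1S(=O)(=O)c1ccccc1` gives 116000 nM in a functional assay on SK-MEL-2 cells (Homo sapiens) for cytotoxicity; a higher number here means a weaker inhibitor, a lower number a stronger inhibitor
compound 2 `O=C1NC(c2ccccc2)CN1S(=O)(=O)c1ccc(Cl)cc1` gives 1430 nM
compound 3 `O=C1NCC(c2ccc(Cl)cc2)N1S(=O)(=O)c1ccc2c(c1)CCC2` gives 161000 nM

Compound 2 carries chloro on the sulfonyl-bound ring, compound 1 lacks it; the change is hydrogen in place of chloro on an aromatic carbon, and the step is an 81-fold higher number from compound 2 to compound 1 (1.91 log units; beyond the scatter). Compound 3 carries the chloro on the other ring and a different sulfonyl part; how its core differs from that of compound 2 is not broken down here. Compound 3 stands within the scatter of compound 1 and far above compound 2.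

Compound 4 `O=C1NCC(c2ccccc2)N1S(=O)(=O)c1ccc2c(c1)CCC2` is not yet measured. It differs from compound 3 by hydrogen in place of chloro on an aromatic carbon, the same kind of change as between compound 2 and compound 1, since both place lines read the same, though the chloro sits on a different ring of the shared core. Because the earlier step of an 81-fold higher number from compound 2 to compound 1 (1.91 log units; beyond the scatter) went strongly toward weaker inhibition, a step of similar direction, a 2.5-fold higher number from compound 3 to compound 4 (0.40 log units; beyond the scatter), is expected here. Compound 4 is therefore expected to give about 400000 nM in this assay, between 100000 nM and 2000000 nM.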

Compound 4, half-maximal inhibitory concentration: 39000 nM
Beside the measured number, compound 4's estimate is 10-fold (1.01 log units) above it, and the stated range ends above it.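

In this assay, hydrogen in place of chloro gives a 4.1-fold lower number from compound 3 to compound 4 (0.62 log units; beyond the scatter), opposite in direction to the earlier step, so neither the direction nor the size of this change carries from one core to the other in this series, and chloro goes with the stronger inhibitor only in the pair of compound 2 and compound 1: the same change on two cores in this assay, an 81-fold higher number (1.91 log units; beyond the scatter) from compound 2 to compound 1 and a 4.1-fold lower number (0.62 log units; beyond the scatter) from compound 3 to compound 4, 330-fold (2.52 log units) apart, beyond the scatter of two such steps.
Among these compounds, the reversal rests on only two pairs, which differ both in the ring that carries the chloro and in the sulfonyl part. These two pairs therefore do not show which of those differences goes with the reversal, and they give no rule for any further core.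

The compounds shown leave open whether the direction of the step follows the ring that carries the chloro or the rest of the core. They also leave open how fluoro, methoxy or an amine in place of chloro would read on each core.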